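The compounds below may be only part of what the source reports. "The series", "measured", "known", "first", "only" and "open" are said of these compounds alone.

Measured compounds:
- compound 1, `CC(=O)O[C@@H]1OC(=O)[C@](C)(C(C)=O)[C@@H]1C`: 7000 nM
- compound 2, `CC(=O)O[C@@H]1OC(=O)[C@](O)(C(C)=O)[C@@H]1C`: > 50000 nM
- compound 3, `CC(=O)[C@@]1(C)C(=O)O[C@@H](OC(=O)C(C)(C)C)[C@H]1C`: 1000 nM

In a functional assay on DA-3 cells for cytotoxicity against DA-3 cell line (Mus musculus), read by MTT assay (a higher number here means a weaker inhibitor, a lower number a stronger inhibitor), compound 1 gives the highest of the two numbers; compound 3 gives a number lower by a 7.0-fold lower number from compound 1 to compound 3 (0.85 log units; beyond the scatter). Compound 2 reaches only a limit in this assay, at the limit of > 50000 nM in this assay, at which 1 of the 3 values shown sits, and is not a number. Compound 4, `CC(=O)O[C@@H]1OC(=O)[C@](C)(C(C)=O)[C@@H]1C(C)C`, is not yet measured; it differs from compound 1 by isopropyl in place of methyl on a saturated ring carbon. Neither measured step touches that ring carbon: an at least 7.1-fold higher number from compound 1 to compound 2 (0.85 log units; beyond the scatter) and a 7.0-fold lower number from compound 1 to compound 3 (0.85 log units; beyond the scatter) change other places. A step of modest size toward a lower number is therefore expected, a 2.3-fold lower number from compound 1 to compound 4 (0.37 log units; beyond the scatter). Compound 4 is estimated at 3000 nM, between 700 nM and 15000 nM.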

Compound 4, half-maximal inhibitory concentration: > 50000 nM
Compound 4: a limit, no number; the forecaster's own chance of this, stated with the estimate: 5%; at least 16-fold (1.22 log units) between middle value and limit.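

For the compounds shown here, this ring carbon, which no earlier step touched, does not tolerate every change: isopropyl in place of methyl gives an at least 7.1-fold higher number from compound 1 to compound 4 (0.85 log units; beyond the scatter). The direction is clear, but the size is not, since in this assay compound 4 gives only a limit and no number, as compound 2 does: the limit of > 50000 nM in this assay, at which 2 of the 4 values shown sit.

As far as these compounds go, whether ethyl or a plain hydrogen at this carbon would keep the activity of compound 1 remains open. So does whether the tert-butyl of compound 3 would restore activity alongside isopropyl.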